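The source may report more compounds than this note shows. Statements on the series, on what has been measured and on what is new or still open speak of the compounds shown alone.

Measured compounds in a functional assay on a cell-free system (plasma) with sterol O-acyltransferase, Soat (Rattus norvegicus) as the target; a lower number here means that less compound is needed, a higher number that more compound is needed for the effect:
- compound 1 `Cc1cc(C)c(NC(=O)N(Cc2ccc(-c3ccsc3)cc2)C2CCCCCC2)c(C)c1`: 0.51 mg/kg
- compound 2 `Cc1cc(C)c(NC(=O)N(Cc2ccc(-n3cccn3)cc2)C2CCCCCC2)c(C)c1`: > 1 mg/kg, a limit of the assay and not a number

Where compound 2 stands: only a limit is known for compound 2 in this assay, namely (the limit of > 1 mg/kg in this assay, at which 1 of the 2 values shown sits), so its true value is not pinned down. For the measured compounds named here, the one measured step, an at least 1.9-fold higher number from compound 1 to compound 2 (0.29 log units; that floor lies within the scatter), is a floor that lies within the scatter; it replaces thiophen-3-yl with 1H-pyrazol-1-yl on an aromatic carbon.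

Compound 3 `Cc1cc(C)c(NC(=O)N(Cc2ccc(-c3cc[nH]n3)cc2)C2CCCCCC2)c(C)c1` differs from compound 2 by 1H-pyrazol-3-yl in place of 1H-pyrazol-1-yl on an aromatic carbon. Going by the values given here, this change keeps the same atoms joined differently and is not covered by any measured step: the step from compound 1 to compound 2 concerns a different pair of groups, and no measured pair has a pyrazol-3-yl. No direction for this change can be derived from the data at hand. For compound 3 the expected step is therefore a step that the limit leaves unreadable from compound 2 to compound 3, one not clearly beyond the scatter from a starting point that is itself only a limit.

Estimated for compound 3 in this assay: 1.5 mg/kg, with a range from 0.5 mg/kg to 5 mg/kg, with a substantial chance that only a limit is reported again.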

Compound 3, dose for half-maximal effect: > 1 mg/kg
Compound 3 ended at the assay's limit; the forecaster's own chance of this, stated with the estimate: 55%; the middle value is on the limit's open side.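

Compound 3 gives > 1 mg/kg in this assay, a limit of the assay and not a number. On the aromatic carbon para to a large group, the pyrazole therefore gives no number in either form, whether joined as 1H-pyrazol-1-yl or as 1H-pyrazol-3-yl with its hydrogen-bond donor, and the step between the two limits cannot be read. Against thiophen-3-yl the result is an at least 1.9-fold higher number from compound 1 to compound 3 (0.29 log units; that floor lies within the scatter), so this second pyrazole adds a floor of the same size but does not carry the comparison beyond the scatter.

On these data alone, it remains open how far either pyrazole lies past the limit, and whether either truly differs from thiophen-3-yl, since the readings so far end here: the limit of > 1 mg/kg in this assay, at which 2 of the 3 values shown sit. Also open is how other groups at the same place would read, for example a phenyl ring, a pyridin-3-yl ring, or a ring bearing an amine or a carboxylic acid, and whether any of them would give a number on the measurable side of the limit.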